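Demethylation of the aryl methyl ether in a pyrazole urea series

The compounds below may be only part of what the source reports. "The series", "measured", "known", "first", "only" and "open" are said of these compounds alone.

Of the compounds shown here, three of one series have been measured, and a fourth awaits its number. Compound 3 `COc1cc(-c2nn(-c3cccc(NC(=O)Nc4cccc(C(F)(F)F)c4)c3)cc2-c2ccncc2)ccc1Cl` gives 1230 nM in a functional assay on Hs-578T cells (Homo sapiens) for inhibition, read by sulforhodamine B assay, with a stated time of 48 h; a higher number here means a weaker inhibitor of growth, a lower number a stronger inhibitor of growth. Compound 2 `COc1cc(-c2nn(-c3cccc(NC(=O)Nc4cc(C(F)(F)F)cc(C(F)(F)F)c4)c3)cc2-c2ccncc2)ccc1Cl` differs from compound 3 by trifluoromethyl in place of hydrogen on an aromatic carbon and in this assay compound 2 gives 1040 nM; the step of a 1.2-fold higher number from compound 2 to compound 3 (0.07 log units; within the scatter) is small. Compound 1 `O=C(Nc1cccc(-n2cc(-c3ccncc3)c(-c3ccc(Cl)c(O)c3)n2)c1)Nc1cccc(C(F)(F)F)c1` carries the free hydroxy group and in this assay compound 1 gives 3310 nM. The change from compound 3 to compound 1 is hydrogen in place of methyl on an oxygen on an aromatic ring, and it gave a 2.7-fold higher number from compound 3 to compound 1 (0.43 log units; beyond the scatter).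

Compound 4 `O=C(Nc1cccc(-n2cc(-c3ccncc3)c(-c3ccc(Cl)c(O)c3)n2)c1)Nc1cc(C(F)(F)F)cc(C(F)(F)F)c1` is the unmeasured member. It differs from compound 2 by hydrogen in place of methyl on an oxygen on an aromatic ring, which is the same change that separates compound 3 from compound 1, now made on the core that bears two trifluoromethyl groups on the urea aryl ring. Among the compounds with values here, since the only measured instance of this change is the step of a 2.7-fold higher number from compound 3 to compound 1 (0.43 log units; beyond the scatter), the writer expects a step of similar size, so that the estimated step from compound 2 to compound 4 is a 2.7-fold higher number from compound 2 to compound 4 (0.43 log units; beyond the scatter). The step between compound 2 and compound 3 lay within the scatter, so the second trifluoromethyl group is not expected to alter the size of the demethylation step. For compound 4 the estimate in this assay is 2800 nM, with a likely range from 1400 nM to 5600 nM.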

Compound 4, concentration for 50% growth inhibition: 1140 nM
Compound 4: middle estimate off by 2.5-fold (0.39 log units), on the high side, outside the stated range (below it).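

In this assay, removing the methyl from the oxygen on the core with two trifluoromethyl groups gave a 1.1-fold higher number from compound 2 to compound 4 (0.04 log units; within the scatter), and set beside the earlier instance of this change, the two steps cannot be told apart: the same change on two cores in this assay, a 2.7-fold higher number (0.43 log units; beyond the scatter) from compound 3 to compound 1 and a 1.1-fold higher number (0.04 log units; within the scatter) from compound 2 to compound 4, 2.5-fold (0.39 log units) apart, within the scatter of two such steps The second trifluoromethyl group, read on the hydroxy core, gave a 2.9-fold lower number from compound 1 to compound 4 (0.46 log units; beyond the scatter), and this step likewise cannot be separated from its counterpart on the methoxy core: the same change on two cores in this assay, a 1.2-fold higher number (0.07 log units; within the scatter) from compound 2 to compound 3 and a 2.9-fold higher number (0.46 log units; beyond the scatter) from compound 4 to compound 1, 2.5-fold (0.39 log units) apart, within the scatter of two such steps So these four compounds give no evidence that either change depends on the core it is made on, yet they do not show that either step carries over unchanged, since each rests on just two pairs in a single assay, and one member of each pair of steps lies within the scatter while the other lies beyond it.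

A repeat of these four compounds would be needed to settle the true size of the methoxy to hydroxy step on each core. The compounds shown also leave open what an ethyl group on that oxygen, or an amine or a carboxylic acid in place of the hydroxy group, would do to growth inhibition on either core.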